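Triazole aryl substituent variation on a shared core

The source may report more compounds than this note shows. Statements on the series, on what has been measured and on what is new or still open speak of the compounds shown alone.

Compound 1 `C=C1C(=O)[C@]23C[C@@]1(O)CC[C@H]2c1ccc(OS(=O)(=O)c2ccc(C)cc2)c(C)c1[C@@H]3Cn1cc(-c2ccccn2)nn1` gives 1810 nM in a functional assay on HL-60 cells (Homo sapiens) for cytotoxicity, read by MTT assay, with a stated time of 4 days; on this read-out higher numbers stand for weaker inhibition and lower numbers for stronger inhibition.
Compound 2 `C=C1C(=O)[C@]23C[C@@]1(O)CC[C@H]2c1ccc(OS(=O)(=O)c2ccc(C)cc2)c(C)c1[C@@H]3Cn1cc(-c2ccc(Cl)cc2)nn1` gives 1260 nM in this assay.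
Compound 3 `C=C1C(=O)[C@]23C[C@@]1(O)CC[C@H]2c1ccc(OS(=O)(=O)c2ccc(C)cc2)c(C)c1[C@@H]3Cn1cc(-c2ccc(C)cc2)nn1` gives 1110 nM in this assay.

Compound 3 stands lowest of the three numbers in this assay, yet every step to it is within the scatter: a 1.6-fold lower number from compound 1 to compound 3 (0.21 log units; within the scatter) and a 1.1-fold lower number from compound 2 to compound 3 (0.06 log units; within the scatter); the remaining step of a 1.4-fold lower number from compound 1 to compound 2 (0.16 log units; within the scatter) is within it as well. Compound 4 `C=C1C(=O)[C@]23C[C@@]1(O)CC[C@H]2c1ccc(OS(=O)(=O)c2ccc(C)cc2)c(C)c1[C@@H]3Cn1cc(-c2ccc(OC)cc2)nn1` differs from compound 3 by methoxy in place of methyl on an aromatic carbon. Going by the values given here, no measured step covers this exchange; the nearest is a 1.1-fold lower number from compound 2 to compound 3 (0.06 log units; within the scatter), a single-group exchange that stayed within the scatter, and the other aryl variations did likewise. A step in this assay no larger than the scatter is therefore expected, a 1.0-fold higher number from compound 3 to compound 4 (0.02 log units; within the scatter). For compound 4 the estimate is 1150 nM, expected to lie between 550 nM and 2400 nM.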

Compound 4, half-maximal inhibitory concentration: 1020 nM
Compound 4: the middle estimate sits 1.1-fold (0.05 log units) above what was measured; the range from low to high includes it.
By their numbers in this assay, from the lowest: compounds 4, 3, 2 and 1 (each within the scatter of the next).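

The 4-methoxyphenyl group, whose oxygen adds a hydrogen-bond acceptor that 4-methylphenyl lacks, leaves the number in this assay within the scatter (a 1.1-fold lower number from compound 3 to compound 4 (0.04 log units; within the scatter)). The same holds against the chloro compound (a 1.2-fold lower number from compound 2 to compound 4 (0.09 log units; within the scatter)) and the pyridin-2-yl compound (a 1.8-fold lower number from compound 1 to compound 4 (0.25 log units; within the scatter)), so all four aryl groups at this position remain unresolved from one another. No evidence is available that bears on this flat response.

From the compounds shown here alone, whether an amine, a carboxylic acid or a longer chain on this aromatic ring would give a step beyond the scatter remains open.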